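A Second Propyl on the Amine of Compound 3

A few compounds are considered here, and "the series" means these few. Any claim that something is new, unique, unknown or untested is made for them only; others in the source may bear on it.

Measured so far:
- compound 1, `COc1ccccc1-c1cc(CN(C)C)ccc1Cl`, gives 1000 nM in an assay on isolated protein for binding affinity to 5-hydroxytryptamine receptor 3A (Homo sapiens); on this read-out higher numbers stand for weaker inhibition and lower numbers for stronger inhibition.
- compound 2, `CCCCNCc1ccc(Cl)c(-c2ccccc2OC)c1`, gives only a limit, > 10000 nM, in this assay.
- compound 3, `CCCNCc1ccc(Cl)c(-c2ccccc2OC)c1`, gives only a limit, > 10000 nM, in this assay.

Compound 3 therefore stands at the edge of what this assay can report, with no number of its own; it shares this with the limit of > 10000 nM in this assay, at which 2 of the 3 values shown sit. Compound 4, `CCCN(CCC)Cc1ccc(Cl)c(-c2ccccc2OC)c1`, differs from compound 3 by propyl in place of hydrogen on an amine nitrogen, turning propylamino into dipropylamino.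

Going by the values given here, two measured steps bear on this. Moving from a dimethylamino to a single longer chain on the nitrogen gave an at least 10-fold higher number from compound 1 to compound 2 (1.00 log units; beyond the scatter) and an at least 10-fold higher number from compound 1 to compound 3 (1.00 log units; beyond the scatter), so a tertiary amine with two small groups did better than a secondary amine with one longer chain. The step that the two limits leave unreadable from compound 2 to compound 3 cannot be read. Compound 4 returns to a tertiary amine, but with two chains much larger than methyl; the data give no measured case of that. The expected step is a number no higher from compound 3 to compound 4 (the limit leaves the size open), and compound 4 is estimated at 10000 nM, within 2000 nM to 50000 nM.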

Compound 4, inhibition constant: > 10000 nM
Compound 4 was reported as a limit; the forecaster's own chance of this, stated with the estimate: 60%; the middle value sits exactly at the limit.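

The value of compound 4 in this assay, > 10000 nM, is a limit and not a number, so the steps to it from compound 2 and from compound 3 cannot be read. Dipropylamino in place of dimethylamino gives an at least 10-fold higher number from compound 1 to compound 4 (1.00 log units; beyond the scatter), which shows that two chains on the amine nitrogen do not by themselves keep the binding of compound 1, and that the size of those chains matters at this position. The set now gathers at one edge of what the read-out can report: the limit of > 10000 nM in this assay, at which 3 of the 4 values shown sit.

Going by these compounds, how far compound 2, compound 3 and compound 4 lie past that limit, and whether they differ from one another, stays open. So does the outcome for an intermediate tertiary amine such as diethylamino, or for an amine closed into a ring such as pyrrolidine.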